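A few compounds are considered here, and "the series" means these few. Any claim that something is new, unique, unknown or untested is made for them only; others in the source may bear on it.

In a functional assay on DU-145 cells (Homo sapiens) for cytotoxicity, read by MTT assay, with stated times of 48 h and 4 h (a higher number here means a weaker inhibitor, a lower number a stronger inhibitor), the measured compounds read:
Compound 1 `COc1ccc(/C=C/c2nc(NCCN3CCCCC3)c3ccccc3n2)cc1OC`: 71600 nM
Compound 2 `COc1ccc(/C=C/c2nc(NCCN(C)C)c3cc(Cl)ccc3n2)cc1OC`: 17900 nM
Compound 3 `COc1ccc(/C=C/c2nc(NCCN(C(C)C)C(C)C)c3cc(Cl)ccc3n2)cc1OC`: > 100000 nM

Compound 3 gives only a limit, not a number (the limit of > 100000 nM in this assay, at which 1 of the 3 values shown sits). Compound 4 `COc1ccc(/C=C/c2nc(NCCN3CCCCC3)c3cc(Cl)ccc3n2)cc1OC` differs from it by one change: piperidin-1-yl in place of diisopropylamino on a saturated chain carbon, two bonds along the chain from a nitrogen on an aromatic ring. Going by the values given here, the one measured step at this place is an at least 5.5-fold higher number from compound 2 to compound 3 (0.74 log units; beyond the scatter), which lies beyond the scatter. The same (2-(piperidin-1-yl)ethyl)amino group occurs, on a core without chlorine, in compound 1 at 71600 nM. On these two grounds, a move toward a lower number in this assay is expected, taking back part of the step to compound 3. The expected change is an at least 2.5-fold lower number from compound 3 to compound 4 (0.39 log units; beyond the scatter). For compound 4 the estimate is 40000 nM, with an expected range from 14000 nM to 100000 nM.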

Compound 4, half-maximal inhibitory concentration: 17200 nM
For compound 4 the middle estimate is 2.3-fold (0.37 log units) above the measured one; low and high end bracket the measured number.
By their numbers in this assay, from the lowest: compounds 4 and 2 (each within the scatter of the next); then compound 1. At a limit, above all of these: compound 3.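

In this assay the diisopropylamino result does not carry over to the piperidin-1-yl ring on this chain, with an at least 5.8-fold lower number from compound 3 to compound 4 (0.76 log units; beyond the scatter), while a 1.0-fold lower number from compound 2 to compound 4 (0.02 log units; within the scatter) leaves piperidin-1-yl and dimethylamino indistinguishable here. Chloro in place of hydrogen on an aromatic carbon can now be read as a change on its own, with a 4.2-fold lower number from compound 1 to compound 4 (0.62 log units; beyond the scatter). Compound 3 itself remains a limit, not a number: the limit of > 100000 nM in this assay, at which 1 of the 4 values shown sits. As far as these compounds go, whether morpholin-4-yl in place of piperidin-1-yl, or a longer chain, would hold the value of compound 4 stays open. So does the size of the chloro step with dimethylamino on the chain.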